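Replacing a Pyrazole with Benzimidazole on the Shared Core

The compounds below may be only part of what the source reports. "The series", "measured", "known", "first", "only" and "open" are said of these compounds alone.

Measured compounds in a functional assay on CWR22R cells (Homo sapiens) for antiproliferative activity, read by CCK-8 assay, with a stated time of 6 days; on this read-out higher numbers stand for weaker inhibition and lower numbers for stronger inhibition:
compound 1 `CCN(c1ccc(C#N)c(Cl)c1)c1cc(-c2cccnc2)ccc1C`: 2000 nM
compound 2 `CCN(c1ccc(C#N)c(Cl)c1)c1cc(-c2cn[nH]c2)ccc1C`: > 30000 nM, a limit of this assay
compound 3 `CCN(c1ccc(C#N)c(Cl)c1)c1cc(-n2cccn2)ccc1C`: > 30000 nM, a limit of this assay

Compound 3 thus stands at the edge of what this assay reports, the same edge described by the limit of > 30000 nM in this assay, at which 2 of the 3 values shown sit. Compound 4 `CCN(c1ccc(C#N)c(Cl)c1)c1cc(-n2cnc3ccccc32)ccc1C` differs from compound 3 by 1H-benzimidazol-1-yl in place of 1H-pyrazol-1-yl on an aromatic carbon. Going by the values given here, two measured steps bear on changes at this place: an at least 15-fold higher number from compound 1 to compound 2 (1.17 log units; beyond the scatter) and an at least 15-fold higher number from compound 1 to compound 3 (1.17 log units; beyond the scatter), both large losses of inhibition. The step that the two limits leave unreadable from compound 2 to compound 3 cannot be sized, since both of its values are limits. With only weak values known for the pyrazole-bearing compounds, compound 4 is expected to remain weak as well. Compound 4 is estimated at 20000 nM, within 3000 nM to 60000 nM, an expected step of an at least 1.5-fold lower number from compound 3 to compound 4 (0.17 log units; that floor lies within the scatter), and a limit rather than a number is a likely outcome.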

Compound 4, half-maximal inhibitory concentration: 3040 nM
The estimate for compound 4 lay 6.6-fold (0.82 log units) above the measured number, and the stated range covers the measured number.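

In this assay, the pyrazole result does not extend to every five-membered aromatic ring at this position: 1H-benzimidazol-1-yl gives an at least 9.8-fold lower number from compound 3 to compound 4 (0.99 log units; beyond the scatter) and an at least 9.8-fold lower number from compound 2 to compound 4 (0.99 log units; beyond the scatter). Both steps start from a limit, not a number: the limit of > 30000 nM in this assay, at which 2 of the 4 values shown sit. Against the pyridin-3-yl group, the change gives a 1.5-fold higher number from compound 1 to compound 4 (0.18 log units; within the scatter), so the added carbon-only six-membered ring brings compound 4 level with compound 1.

Still open, on these data alone, is how an amine or a carboxylic acid on that added ring would shift the number. The compounds shown also leave open whether any group at this position can clearly surpass pyridin-3-yl.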